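Adding a Third Methoxy Group to Compound 3

The compounds below may be only part of what the source reports. "The series", "measured", "known", "first", "only" and "open" are said of these compounds alone.

Compound 1 `Nc1cc(N)c2nc(-c3ccccc3)c(Oc3ccc(Cl)c(Cl)c3)nc2c1`: in a functional assay on CAKI-1 cells (Homo sapiens) for inhibition, read by sulforhodamine B assay, with a stated time of 48 h (a higher number here means that more compound is tolerated, a lower number that less compound is tolerated), compound 1 gives < 100000 nM, which is a limit of the assay.
Compound 2 `Nc1cc(N)c2nc(-c3ccccc3)c(NCc3ccc(Cl)c(Cl)c3)nc2c1`: in this assay compound 2 gives < 100000 nM, also a limit.
Compound 3 `COc1ccc(CNc2nc3cc(N)cc(N)c3nc2-c2ccccc2)cc1OC`: in this assay compound 3 gives 53700 nM.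

Among the measured compounds shown here, compound 3 thus holds the only definite number; the other two values sit at a limit (the limit of < 100000 nM in this assay, at which 2 of the 3 values shown sit). The step that the limit leaves unreadable from compound 2 to compound 3 cannot be sized. Compound 4 `COc1cc(CNc2nc3cc(N)cc(N)c3nc2-c2ccccc2)cc(OC)c1OC` differs from compound 3 by methoxy in place of hydrogen on an aromatic carbon. For the measured compounds named here, no measured step touches this position, so nothing points to a change beyond the scatter, and the step from compound 3 to compound 4 is expected to be a 1.1-fold lower number from compound 3 to compound 4 (0.03 log units; within the scatter). Compound 4 is therefore estimated at 50000 nM, with a range from 20000 nM to 120000 nM.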

Compound 4, concentration lethal to 50% of the cells: 31600 nM
For compound 4 the middle estimate is 1.6-fold (0.20 log units) above the measured one, within the range that was stated.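

At this position, on an aromatic carbon ortho to a methoxy group, methoxy in place of hydrogen gives a 1.7-fold lower number from compound 3 to compound 4 (0.23 log units; within the scatter). Among the compounds shown here, this is the first measured step at this position, and the third methoxy group does not separate compound 4 from compound 3 in this assay.

On these data alone, whether an amine or a carboxylic acid on this same carbon would give a step beyond the scatter remains open. The step from compound 2 to compound 3 also remains unreadable: the limit of < 100000 nM in this assay, at which 2 of the 4 values shown sit.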